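Replacing 4-phenylpiperazin-1-yl with propyl at the assay limit

The source may hold more compounds than are shown below. What is called first, only, known or untested is meant among the compounds shown, and "the series" means these compounds.

Measured in a functional assay on the whole organism with Mus musculus as the target, in the rotarod test; a lower number here means that less compound is needed, a higher number that more compound is needed for the effect:
Compound 1 `CN1CCN(CC(=O)NCC(=O)N(C)c2ccc(Cl)cc2C(=O)c2ccccc2Cl)CC1`: > 100 mg/kg, a limit
Compound 2 `CC(C)C(=O)NCC(=O)N(C)c1ccc(Cl)cc1C(=O)c1ccccc1Cl`: > 100 mg/kg, a limit
Compound 3 `CN(C(=O)CNC(=O)CN1CCN(c2ccccc2)CC1)c1ccc(Cl)cc1C(=O)c1ccccc1Cl`: > 100 mg/kg, a limit

On the numbers shown, compound 3 stands at > 100 mg/kg, which is a limit of the assay and not a number. It has company there: the limit of > 100 mg/kg in this assay, at which 3 of the 3 values shown sit.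

Compound 4 `CCCCC(=O)NCC(=O)N(C)c1ccc(Cl)cc1C(=O)c1ccccc1Cl` has not yet been measured. It differs from compound 3 by propyl in place of 4-phenylpiperazin-1-yl on a saturated chain carbon bound to a carbonyl carbon, with propyl in place of 4-phenylpiperazin-1-yl on a saturated chain carbon bound to a carbonyl carbon.

Among the compounds with values here, two measured steps bear on this change. The closer one is a step that the two limits leave unreadable from compound 1 to compound 2, in which isopropyl replaces (4-methylpiperazin-1-yl)methyl on a carbonyl carbon. The other is a step that the two limits leave unreadable from compound 1 to compound 3, in which phenyl replaces methyl on an amine nitrogen in a ring. Neither has a size that can be read, so neither offers a direction or a magnitude to carry over to this assay. The most likely expectation is that compound 4 also reaches the limit, with no definite shift. The expected step is a step that the limit leaves unreadable from compound 3 to compound 4, an estimate that rests on limits alone. For compound 4 the estimated value is 150 mg/kg, with an expected range from 60 mg/kg to 400 mg/kg.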

Compound 4, dose for half-maximal effect: 90 mg/kg
Beside the measured number, compound 4's estimate is 1.7-fold (0.22 log units) above it, within the range that was stated.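

In this assay, within the data shown here, compound 4 gives the only value of the series that is a number and not a limit, and the others sit together: the limit of > 100 mg/kg in this assay, at which 3 of the 4 values shown sit.

Propyl in place of 4-phenylpiperazin-1-yl gives an at least 1.1-fold lower number from compound 3 to compound 4 (0.04 log units; that floor lies within the scatter), butyl in place of isopropyl on a carbonyl carbon gives an at least 1.1-fold lower number from compound 2 to compound 4 (0.04 log units; that floor lies within the scatter), and propyl in place of 4-methylpiperazin-1-yl gives an at least 1.1-fold lower number from compound 1 to compound 4 (0.04 log units; that floor lies within the scatter), while the steps among compound 1, compound 2 and compound 3 cannot be read. The result thus shows that a compound with a small open chain at this place can give a readable dose, but no change in that dose is established, and compound 2, which also carries neither piperazine group, remains at a limit.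

The compounds shown leave open whether any group at this saturated chain carbon moves the dose clearly beyond the scatter. A longer chain such as hexyl, a shorter one such as ethyl, or a carboxylic acid or a simple amine at the same place would be needed to tell whether the number follows the chain or stays close to the limit.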